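Trimming an ethoxy to a methoxy on a shared core

This account rests on a few compounds, and the source may have more. Where it says the series, first, only, none or still open, it means among the compounds named here.

Compound 1 `Cc1ccc2nc(C(=O)Nc3c(F)cc(-c4cccc(F)c4)cc3F)c(C)c(O)c2c1` and compound 2 `CCc1ccc2nc(C(=O)Nc3c(F)cc(-c4cccc(F)c4)cc3F)c(C)c(O)c2c1` share one core and differ only in a short side chain. In a functional assay on Hep 3B2 cells (Homo sapiens) for antiproliferative activity, read by MTT assay, with a stated time of 24 h, tested at 100 ug/mL (on this read-out lower numbers stand for a weaker effect and higher numbers for a stronger effect at the one concentration tested), compound 1 gives 68.3%, and compound 2 gives 63.2%. The change hydrogen in place of methyl on a saturated chain carbon bound to an aromatic carbon thus made a step of a number 5.1 percentage points higher from compound 2 to compound 1 (within the scatter). Compound 3 `CCOc1ccc2nc(C(=O)Nc3c(F)cc(-c4cccc(F)c4)cc3F)c(C)c(C(=O)O)c2c1` is built differently; how it differs from compound 2 is not broken down here. In this assay compound 3 gives 65.3%, a number within the usual scatter of those of compound 1 and compound 2. Compound 4 `COc1ccc2nc(C(=O)Nc3c(F)cc(-c4cccc(F)c4)cc3F)c(C)c(C(=O)O)c2c1` is not yet measured and differs from compound 3 by hydrogen in place of methyl on a saturated chain carbon bound to an oxygen on an aromatic ring. Going by the values given here, this is the same kind of change as the one from compound 2 to compound 1, but not the same: there the saturated chain carbon was bound to an aromatic carbon, here it is bound to an oxygen on an aromatic ring. The earlier step of a number 5.1 percentage points higher from compound 2 to compound 1 (within the scatter) stayed within the scatter. On that basis a similarly small step is expected, a number 2.3 percentage points lower from compound 3 to compound 4 (within the scatter). Compound 4 is therefore expected to give about 63%, with a likely range from 50% to 76%.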

Compound 4, a percentage reported as inhibition, at one concentration (the size of the read-out at that concentration, not a potency): 28.3%
Compound 4: the middle estimate sits 34.7 percentage points above what was measured; measured number outside the range, below it.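

In this assay, trimming ethoxy to methoxy gave a step of a number 37 percentage points lower from compound 3 to compound 4 (beyond the scatter). The ethyl to methyl trim on the other core gave no such drop, so this kind of change did not carry over from one core to the other: the same change on two cores in this assay, a number 5.1 percentage points higher (within the scatter) from compound 2 to compound 1 and a number 37 percentage points lower (beyond the scatter) from compound 3 to compound 4, 42.1 percentage points apart, beyond the scatter of two such steps

This shows that a small step on one core is no safe guide to the step on another in this series, but it does not show why the two steps part. The two pairs differ both in whether the core carries a hydroxyl or a carboxylic acid and in whether the saturated chain carbon is bound to an aromatic carbon or to an oxygen on an aromatic ring, and a single pair of each kind cannot separate those two differences.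

The compounds shown leave open what the same trim would do with a methoxy and an ethoxy on the hydroxyl-bearing core, or with a methyl and an ethyl on the carboxylic acid-bearing core. They also leave open how a longer chain such as propoxy, or an amine in that place, would read in this assay.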